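Trifluoromethyl Oxetane Carbamate on the Compound 1 Core

A few compounds are considered here, and "the series" means these few. Any claim that something is new, unique, unknown or untested is made for them only; others in the source may bear on it.

Measured so far:
compound 1 `Cc1nc(S(C)(=O)=O)ccc1Oc1ncnc(OC2CCN(C(=O)OC(C)(C)C#N)CC2)c1F` 1320 nM
compound 2 `Cc1nc(S(C)(=O)=O)ccc1Oc1ncnc(OC2CCN(C(=O)OC3COC3)CC2)c1F` 2500 nM
compound 3 `Cc1nc(S(C)(=O)=O)ccc1Oc1ncnc(OC2CCN(C(=O)OC3(C(F)(F)F)CCC3)CC2)c1F` 63.3 nM

In a functional assay on isolated protein for inhibition of Glucose-dependent insulinotropic receptor (Rattus norvegicus), read by HTRF and cAMP accumulation (a higher number here means that more compound is needed for the effect, a lower number that less compound is needed), compound 1 gives the second highest of the three numbers; compound 2 sits within the scatter of it, while compound 3 stands far lower. The step of a 1.9-fold higher number from compound 1 to compound 2 (0.28 log units; within the scatter) is small, but a 21-fold lower number from compound 1 to compound 3 (1.32 log units; beyond the scatter) is large, as is a 39-fold lower number from compound 2 to compound 3 (1.60 log units; beyond the scatter). Compound 4 `Cc1nc(S(C)(=O)=O)ccc1Oc1ncnc(OC2CCN(C(=O)OC3(C(F)(F)F)COC3)CC2)c1F` changes compound 1 thus: 3-(trifluoromethyl)oxetan-3-yl in place of 1-cyano-1-methylethyl on an oxygen next to a carbonyl group. The entering group carries the trifluoromethyl of compound 3 together with the ring oxygen of compound 2, so the large drop from compound 1 to compound 3 bears most on it, tempered by the small rise from compound 1 to compound 2. A clearly lower number is therefore expected, a 6.6-fold lower number from compound 1 to compound 4 (0.82 log units; beyond the scatter). For compound 4 the estimate is 200 nM, between 60 nM and 700 nM.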

Compound 4, half-maximal effective concentration: 342 nM
Compound 4: the middle estimate sits 1.7-fold (0.23 log units) below what was measured; the range from low to high includes it.
By their numbers in this assay, from the lowest: compound 3; then compound 4; then compounds 1 and 2 (each within the scatter of the next).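

Trifluoromethyl in place of hydrogen on the oxetane ring carbon gives a clear gain, a 7.3-fold lower number from compound 2 to compound 4 (0.86 log units; beyond the scatter), so this position responds to that one group even with the ring oxygen kept. Still, 3-(trifluoromethyl)oxetan-3-yl falls short of 1-(trifluoromethyl)cyclobutyl, with a 5.4-fold higher number from compound 3 to compound 4 (0.73 log units; beyond the scatter), while keeping an advantage over 1-cyano-1-methylethyl, with a 3.9-fold lower number from compound 1 to compound 4 (0.59 log units; beyond the scatter). No measured evidence accounts for these differences.

A plain cyclobutyl or a tert-butyl group on the oxygen next to the carbonyl group would show how much of the gain rests on trifluoromethyl alone.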